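The source may report more compounds than this note shows. Statements on the series, on what has been measured and on what is new or still open speak of the compounds shown alone.

Among the measured compounds shown here, in an ADME assay on microsomes from liver (Mus musculus) for metabolic stability, read by LC-MS, using NADPH, tested at 1 uM (a higher number here means that the compound lasts longer, a lower number that the compound disappears faster), compound 1 `CC(=O)NC/C=C\CN(C)C[C@H]1O[C@@H](n2cnc3c(N)ncnc32)[C@H](OC(C)=O)[C@@H]1OC(C)=O` gives 0.11 h, the only true number so far. Compound 2 `Cc1nc2c(N)ncnc2n1[C@@H]1O[C@H](CN(C)C/C=C\CNC(=O)OC(C)(C)C)[C@H]2OC(C)(C)O[C@H]21` gives only a limit, < 0.0417 h. Compound 3 `Cc1nc2c(N)ncnc2n1[C@@H]1O[C@H](CN(C/C=C\CNC(=O)OC(C)(C)C)C2CC2)[C@H]2OC(C)(C)O[C@H]21` also gives only a limit, < 0.0417 h, and so stands at the limit of < 0.0417 h in this assay, at which 2 of the 3 values shown sit. For the measured compounds named here, the one measured step is a step that the two limits leave unreadable from compound 2 to compound 3, which offers no size to carry forward. Compound 4 `Cc1nc2c(N)ncnc2n1[C@@H]1O[C@H](CN(C/C=C\CN)C2CC2)[C@H]2OC(C)(C)O[C@H]21` has hydrogen in place of tert-butoxycarbonyl on an amine nitrogen. Going by the values given here, no measured step covers this change, so neither its size nor its direction can be read from the data. The expected step of an at least 1.1-fold higher number from compound 3 to compound 4 (0.07 log units; that floor lies within the scatter) is small, and this assay may again return only a limit. For compound 4 the estimated half-life is 0.05 h, with an expected range from 0.025 h to 0.15 h.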

Compound 4, half-life: > 1.5 h
Compound 4 was reported as a limit (the forecaster's own chance of this, stated with the estimate: 50%); middle value at least 30-fold (1.47 log units) away from the limit.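

In this assay, the tert-butoxycarbonyl group on this amine nitrogen proves to matter greatly: hydrogen in its place gives an at least 35-fold higher number from compound 3 to compound 4 (1.55 log units; beyond the scatter). Among the compounds shown here, the step from compound 2 to compound 3 cannot be read, so this is the first change with a readable size. Compound 4 sits at a limit of the assay, not at a true number: the limit of > 1.5 h in this assay, at which 1 of the 4 values shown sits.

On these data alone, how long the half-life of compound 4 really is remains open. So does whether a methyl group or a smaller carbamate such as methoxycarbonyl on this nitrogen would keep the same gain.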